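This account rests on a few compounds, and the source may have more. Where it says the series, first, only, none or still open, it means among the compounds named here.

Measured so far:
- compound 1, `O=S(=O)(c1ccccc1)c1nc2ccccc2nc1Nc1ccc(C(F)(F)F)cc1`: 3550 nM
- compound 2, `Cc1ccc(S(=O)(=O)c2nc3ccccc3nc2Nc2ccccc2)cc1`: 1060 nM
- compound 3, `Cc1ccc(S(=O)(=O)c2nc3ccccc3nc2Nc2ccc(F)cc2)cc1`: 13100 nM

All three were tested in a functional assay on PC-3 cells (Homo sapiens) for cytotoxicity, read by MTT assay, with a stated time of 72 h; on this read-out higher numbers stand for weaker inhibition and lower numbers for stronger inhibition. Compound 3 stands at the high end of this small set: its number is the highest of the three, with compound 1 nearest and compound 2 furthest away. Going by the values given here, the one single-point step that is known, a 12-fold higher number from compound 2 to compound 3 (1.09 log units; beyond the scatter), shows how much weight a small change on the aniline ring can carry here.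

Compound 4, `Cc1ccc(S(=O)(=O)c2nc3ccccc3nc2Nc2ccc(C(F)(F)F)cc2)cc1`, takes the next step from compound 3: trifluoromethyl in place of fluoro on an aromatic carbon. Among the compounds with values here, no measured pair isolates exactly this exchange. The closest guide is compound 1, which already carries the trifluoromethyl group on the aniline ring but differs from compound 4 on the sulfonyl side as well; compound 1 gives 3550 nM in this assay, a number below that of compound 3. Taken together with the step from compound 2 to compound 3, this suggests that the substituent on this ring matters, but it does not fix the direction for the trifluoromethyl group on its own. The expectation is a modest move toward lower numbers, a 2.6-fold lower number from compound 3 to compound 4 (0.42 log units; beyond the scatter), with wide uncertainty. For compound 4 the estimated value is 5000 nM, within a range from 1500 nM to 16000 nM.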

Compound 4, half-maximal inhibitory concentration: 2540 nM
The estimate for compound 4 lay 2.0-fold (0.29 log units) above the measured number, and the stated range covers the measured number.
By their numbers in this assay, from the lowest: compound 2; then compounds 4 and 1 (each within the scatter of the next); then compound 3.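

In this assay the change at this position, para to a large group, partly reverses the cost of fluoro, with a 5.2-fold lower number from compound 3 to compound 4 (0.71 log units; beyond the scatter), yet the trifluoromethyl compound does not return to the level of the compound with hydrogen there, with a 2.4-fold higher number from compound 2 to compound 4 (0.38 log units; beyond the scatter). The three groups therefore do not line up by heavy-atom count: fluoro, with 1 heavy atom, gives the highest number, while trifluoromethyl, with 4, falls between fluoro and hydrogen, so a larger group on this ring does not simply mean a higher or a lower number. Going by these compounds alone, the first pair to isolate the methyl group on the sulfonyl side shows that, with trifluoromethyl on the aniline ring, adding it leaves the numbers within the usual scatter, with a 1.4-fold lower number from compound 1 to compound 4 (0.15 log units; within the scatter).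

Still open, from the compounds shown here alone, is where an amine or a carboxylic acid would fall at this position, and whether hydrogen, fluoro and trifluoromethyl keep this order without that methyl group. Nothing available accounts for the order seen among these compounds.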